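This account rests on a few compounds, and the source may have more. Where it says the series, first, only, none or still open, it means among the compounds named here.

Of the compounds shown here, two have numbers so far. In an ADME assay on GES1 cells (Homo sapiens) for inhibition, read by MTT assay, with a stated time of 72 h (on this read-out lower numbers stand for stronger inhibition and higher numbers for weaker inhibition), compound 1 `Cc1cc(Nc2cc(-c3cccs3)[nH]n2)n2nc(SCc3ccc(Br)cc3)nc2n1` gives 38700 nM, and compound 2 `Cc1cc(Nc2cc(-c3ccccc3)[nH]n2)n2nc(SCc3ccccc3Br)nc2n1` gives 41100 nM, the highest of the two numbers, though the two values lie within the scatter of each other. Among the compounds with values here, no pair of measured compounds differs in only one place, so no measured step is available. Compound 3 `Cc1cc(Nc2cc(-c3ccccc3)[nH]n2)n2ncnc2n1` differs from compound 2 by hydrogen in place of (2-bromobenzyl)sulfanyl on an aromatic carbon. No change of this kind has been measured here; the step in this assay is expected to be small, more likely toward a higher number than a lower one. Compound 3 is therefore estimated at 55000 nM, with a range of 25000 nM to 120000 nM. This expectation amounts to a 1.3-fold higher number from compound 2 to compound 3 (0.13 log units; within the scatter).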

Compound 3, half-maximal inhibitory concentration: > 50000 nM
Compound 3 was reported as a limit (the forecaster's own chance of this, stated with the estimate: 20%); the middle value is on the limit's open side.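

In this assay, within the data shown here, the first measured step at this position, hydrogen in place of (2-bromobenzyl)sulfanyl, gives an at least 1.2-fold higher number from compound 2 to compound 3 (0.08 log units; that floor lies within the scatter) and no lower number. The value of compound 3 is a limit, so this step is only a floor and its full size cannot be read: the limit of > 50000 nM in this assay, at which 1 of the 3 values shown sits. The high number of compound 2 therefore does not depend on the (2-bromobenzyl)sulfanyl group. As far as these compounds go, how far beyond the limit compound 3 lies stays open, as does whether an amine or a carboxylic acid on this aromatic carbon would bring the number down.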